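Closing the Amino Side Chain into a Ring

The source may hold more compounds than are shown below. What is called first, only, known or untested is meant among the compounds shown, and "the series" means these compounds.

Three compounds have so far been measured in an assay on isolated protein for inhibition of interferon-induced, double-stranded RNA-activated protein kinase (Homo sapiens), read by luminescence, with a stated time of 10 min; on this read-out higher numbers stand for weaker inhibition and lower numbers for stronger inhibition:

Compound 1 `Cc1[nH]c2ccccc2c1-c1ccnc(NCCO)n1` gives 11000 nM.
Compound 2 `CSc1cccc(N/C=C2\C(=O)Nc3ccccc32)c1` gives 2500 nM.
Compound 3 `COCCCNc1nccc(-c2c(C)[nH]c3ccccc23)n1` gives 1500 nM.

Compound 3 holds the lowest number of the three. Compound 2 sits within the scatter of it, so the two cannot be ranked; compound 1 stands clearly apart, shown by a 7.3-fold lower number from compound 1 to compound 3 (0.87 log units; beyond the scatter).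

Compound 4 `Cc1[nH]c2ccccc2c1-c1ccnc(N2CCCC2)n1` differs from compound 3 by pyrrolidin-1-yl in place of (3-methoxypropyl)amino on an aromatic carbon. Within the data shown here, the only measured step touching this position is a 7.3-fold lower number from compound 1 to compound 3 (0.87 log units; beyond the scatter), which swapped one open chain for another on the same nitrogen; no measured compound closes that chain into a ring. The expectation is therefore a step of a 2.0-fold higher number from compound 3 to compound 4 (0.30 log units; within the scatter), not beyond the scatter, with wide uncertainty. Compound 4 is estimated at 3000 nM, between 800 nM and 12000 nM.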

Compound 4, half-maximal inhibitory concentration: > 100000 nM
Compound 4: no number, only a limit; the forecaster's own chance of this, stated with the estimate: 10%; middle value at least 33-fold (1.52 log units) from the limit.
By their numbers in this assay, from the lowest: compounds 3 and 2 (each within the scatter of the next); then compound 1. At a limit, above all of these: compound 4.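

The earlier compounds shown here only swapped one open chain for another on this nitrogen, whereas pyrrolidin-1-yl, a ring with no hydrogen-bond donor, gives an at least 66-fold higher number from compound 3 to compound 4 (1.82 log units; beyond the scatter) and an at least 9.0-fold higher number from compound 1 to compound 4 (0.95 log units; beyond the scatter). So this position can respond far more strongly than the earlier step showed. Compound 4 reads only as a limit: the limit of > 100000 nM in this assay, at which 1 of the 4 values shown sits.

On these data alone, the ring and the loss of the donor arrive together, so their shares stay unknown. Dimethylamino, an open group without the donor, would help to separate them.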